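This account rests on a few compounds, and the source may have more. Where it says the series, first, only, none or still open, it means among the compounds named here.

Measured in a functional assay on SK-OV-3 cells (Homo sapiens) for inhibition, read by CCK-8 assay, with a stated time of 70 h; on this read-out lower numbers stand for stronger inhibition and higher numbers for weaker inhibition:
Compound 1 `c1ccc(COc2ccc(OCCOCCNC3CCCC3)cc2)cc1`: 24800 nM
Compound 2 `c1ccc(COc2ccc(OCCOCCNc3ccccc3)cc2)cc1`: > 100000 nM (a limit of the assay)
Compound 3 `c1ccc(COc2ccc(OCCOCCNc3cc[nH]c3)cc2)cc1`: 11300 nM

Compound 1, at 24800 nM, has the higher of the two actual numbers in this assay. Compound 4 `Nc1ccccc1COc1ccc(OCCOCCNC2CCCC2)cc1` differs from it by amino in place of hydrogen on an aromatic carbon, which turns benzyl into 2-aminobenzyl. The measured steps change only the group on the amine nitrogen: a 2.2-fold lower number from compound 1 to compound 3 (0.34 log units; beyond the scatter) and an at least 4.0-fold higher number from compound 1 to compound 2 (0.60 log units; beyond the scatter). Within the data shown here, they show that this series can respond to a single change, but no measured step touches the benzyl group. No clear direction is therefore expected, and any shift should be small. The estimate means a 1.2-fold lower number from compound 1 to compound 4 (0.09 log units; within the scatter), an expected step within the scatter. For compound 4 the expected half-maximal inhibitory concentration is 20000 nM, with an estimated range of 7000 nM to 60000 nM.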

Compound 4, half-maximal inhibitory concentration: 14000 nM
For compound 4 the middle estimate is 1.4-fold (0.15 log units) above the measured one; the range from low to high includes it.
By their numbers in this assay, from the lowest: compounds 3, 4 and 1 (each within the scatter of the next, the first and the last beyond it). At a limit, above all of these: compound 2.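

Replacing benzyl with 2-aminobenzyl gives compound 4 a value that cannot be told apart from that of compound 1 in this assay: the step is a 1.8-fold lower number from compound 1 to compound 4 (0.25 log units; within the scatter). This aromatic ring therefore carries an amino group without a loss of inhibition, whereas changes to the group on the amine nitrogen gave steps beyond the scatter. Nothing available explains this step. On these data alone, whether a hydroxyl, a methyl or a nitro group at this place would read the same remains open, as does the effect of combining 2-aminobenzyl with the 1H-pyrrol-3-yl group of compound 3.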